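Notes on compound 4: replacing the trifluoromethylphenyl group

This account rests on a few compounds, and the source may have more. Where it says the series, first, only, none or still open, it means among the compounds named here.

In a functional assay on HL-60 cells (Homo sapiens) for inhibition, read by MTT assay, with a stated time of 72 h (on this read-out higher numbers stand for weaker inhibition and lower numbers for stronger inhibition), compound 3 `Cc1nc(-c2ccccc2)c(C(=O)N2CCN(c3ccccc3C(F)(F)F)CC2)o1` gives 120 nM, within the scatter of compound 1 `Cc1ccc(N2CCN(C(=O)c3oc(C)nc3-c3ccccc3)CC2)c(C)c1` at 101 nM, as shown by a 1.2-fold higher number from compound 1 to compound 3 (0.07 log units; within the scatter). Only compound 2 `COc1cccc(N2CCN(C(=O)c3oc(C)nc3-c3ccccc3)CC2)c1`, at 34.8 nM, stands apart from both.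

The step to compound 4 `CC(=O)Nc1cccc(N2CCN(C(=O)c3oc(C)nc3-c3ccccc3)CC2)c1` is 3-acetamidophenyl in place of 2-(trifluoromethyl)phenyl on an amine nitrogen in a ring.

Within the data shown here, the closest precedent is the 3-methoxyphenyl group of compound 2, which gives a 3.4-fold higher number from compound 2 to compound 3 (0.54 log units; beyond the scatter) and a 2.9-fold lower number from compound 1 to compound 2 (0.46 log units; beyond the scatter). Both steps are modest and beyond the scatter, and they favour the 3-methoxyphenyl group. Among the measured compounds shown here, that evidence rests on one compound, and no measured compound carries an acetamido group, so only part of that gap is carried over and the range stays wide.

The expected change in this assay is a modest drop in the number, estimated as a 2.2-fold lower number from compound 3 to compound 4 (0.34 log units; beyond the scatter). Compound 4 is estimated at 55 nM, with an expected range of 18 nM to 170 nM.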

Compound 4, half-maximal inhibitory concentration: 329 nM
Compound 4: middle estimate off by 6.0-fold (0.78 log units), on the low side, outside the stated range (above it).
By their numbers in this assay, from the lowest: compound 2; then compounds 1 and 3 (each within the scatter of the next); then compound 4.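

In this assay, the 3-acetamidophenyl group on the amine nitrogen in the ring gives the highest number of the four compounds, with both (a 2.7-fold higher number from compound 3 to compound 4 (0.44 log units; beyond the scatter)) and (a 3.3-fold higher number from compound 1 to compound 4 (0.51 log units; beyond the scatter)) beyond the scatter. The largest step is acetamido in place of methoxy on an aromatic carbon (a 9.5-fold higher number from compound 2 to compound 4 (0.98 log units; beyond the scatter)), so the low number of compound 2 does not carry over to every 3-substituted phenyl group. Nothing measured on these compounds gives a reason for this rise.

The compounds shown leave open whether a 3-aminophenyl or 3-hydroxyphenyl group at this nitrogen would stand nearer to compound 2 or to compound 4. They also leave open how a 2-methoxyphenyl or 4-methoxyphenyl group would compare with the 3-methoxyphenyl group of compound 2.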